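This account rests on a few compounds, and the source may have more. Where it says the series, first, only, none or still open, it means among the compounds named here.

In an ADME assay on HCT-116 cells (Homo sapiens) for antiproliferative activity (on this read-out lower numbers stand for stronger inhibition and higher numbers for weaker inhibition), compound 1 `COc1ccc(C(N)=O)cc1/C=C/c1ccccc1` gives 36000 nM. Compound 2 `COc1ccc(C(N)=O)cc1/C=C/c1ccc(C(C)(C)C)cc1` gives 20000 nM, and compound 3 `COc1ccc(C(N)=O)cc1/C=C/c1ccc([N+](=O)[O-])cc1` gives 22000 nM. Compound 1 therefore stands level with both of the others, as all three values lie within the scatter of one another.

Compound 4 `COc1ccc(C(N)=O)cc1/C=C/c1ccccc1Cl` has not yet been measured. It keeps the core of compound 1 and makes a single change: chloro in place of hydrogen on an aromatic carbon. This is chloro in place of hydrogen on an aromatic carbon of a six-membered aromatic ring of carbon only, ortho to a large group.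

For the measured compounds named here, two measured steps bear on this change, as each also starts from compound 1 and makes one single substitution. With tert-butyl the result is a 1.8-fold lower number from compound 1 to compound 2 (0.26 log units; within the scatter), and with nitro it is a 1.6-fold lower number from compound 1 to compound 3 (0.21 log units; within the scatter). Neither of these two different groups moved the number beyond the scatter. However, no measured step shows a change at the place that chloro occupies, so this comparison is only a rough guide. No step beyond the scatter is expected for chloro, and any small shift would most plausibly follow the same direction.

The expected step is a 1.3-fold lower number from compound 1 to compound 4 (0.11 log units; within the scatter). For compound 4 the estimated value is 28000 nM, with an expected range from 14000 nM to 55000 nM.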

Compound 4, half-maximal inhibitory concentration: > 50000 nM
Compound 4 was reported as a limit (the forecaster's own chance of this, stated with the estimate: 10%); at least 1.7-fold (0.25 log units) between middle value and limit.
By their numbers in this assay, from the lowest: compounds 2, 3 and 1 (each within the scatter of the next). At a limit, above all of these: compound 4.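

Compound 4 is the only compound shown that stands at a limit in this assay, so it has a bound and no exact number: the limit of > 50000 nM in this assay, at which 1 of the 4 values shown sits. Its step is an at least 1.3-fold higher number from compound 1 to compound 4 (0.14 log units; that floor lies within the scatter), which means that only a floor is known, and the true size of the change from hydrogen to chloro could be small or much larger. For the compounds shown here, what this adds to the earlier compounds is a first reading for a group on an aromatic carbon ortho to a large group: chloro at this place brings no sign of stronger inhibition, although whether it weakens inhibition beyond the scatter cannot be read.

The compounds shown leave open how far compound 4 really lies from compound 1, since a limit cannot settle that, and whether the result belongs to chloro itself or to this place on the ring. A methyl group, a methoxy group or an amine at the same place, or chloro in the place held by tert-butyl in compound 2, would be needed to separate those two readings.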